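One Ring Swap on the Sulfonyl Sulfur: Compound 4

A few compounds are considered here, and "the series" means these few. Any claim that something is new, unique, unknown or untested is made for them only; others in the source may bear on it.

The measured compounds, all tested in a functional assay on DLD-1 cells (Homo sapiens) for antiproliferative activity, read by CellTiter-Glo, with a stated time of 72 h; on this read-out higher numbers stand for weaker inhibition and lower numbers for stronger inhibition:
Compound 1, `CC1CCN(C2CCN(S(=O)(=O)c3cn(C)cn3)CC2)CC1`, reaches only the limit of > 5000 nM, not a number.
Compound 2, `Cc1cccc(S(=O)(=O)N2CCC(N3CCC(C)CC3)CC2)c1`, gives 25 nM.
Compound 3, `CC1CCN(C2CCN(S(=O)(=O)c3ccc(Cl)c(Cl)c3)CC2)CC1`, gives 2.9 nM.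

Compound 3 therefore holds the lowest of the two real numbers; the nearest is compound 2, separated by an 8.6-fold lower number from compound 2 to compound 3 (0.94 log units; beyond the scatter). Compound 1 stands apart at the limit of > 5000 nM in this assay, at which 1 of the 3 values shown sits.

Compound 4 is `CC1CCN(C2CCN(S(=O)(=O)c3cccnc3F)CC2)CC1`. It differs from compound 3 in one place: 2-fluoropyridin-3-yl in place of 3,4-dichlorophenyl on a sulfonyl sulfur.

Going by the values given here, two measured steps bear on this change, since both end at compound 3 and both alter the same group on the sulfonyl sulfur: an at least 1700-fold lower number from compound 1 to compound 3 (3.23 log units; beyond the scatter) and an 8.6-fold lower number from compound 2 to compound 3 (0.94 log units; beyond the scatter). Read backwards, each shows that replacing the 3,4-dichlorophenyl with another ring raised the number, modestly when the ring was 3-methylphenyl and beyond the assay's limit when it was 1-methyl-1H-imidazol-4-yl. The 2-fluoropyridin-3-yl that enters is a six-membered aromatic ring with one hetero atom, closer to the ring of compound 2 than to that of compound 1, so a rise that is clear but short of the limit is expected, as a 21-fold higher number from compound 3 to compound 4 (1.32 log units; beyond the scatter).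

Compound 4 is thus estimated at 60 nM in this assay, with a likely range from 10 nM to 500 nM.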

Compound 4, half-maximal inhibitory concentration: > 5000 nM
Compound 4: no number, only a limit (the forecaster's own chance of this, stated with the estimate: 10%); middle value at least 83-fold (1.92 log units) away from the limit.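

In this assay, the swap of rings on the sulfonyl sulfur brings an at least 1700-fold higher number from compound 3 to compound 4 (3.23 log units; beyond the scatter), and measured against the 3-methylphenyl ring the same 2-fluoropyridin-3-yl brings an at least 200-fold higher number from compound 2 to compound 4 (2.30 log units; beyond the scatter). This shows that a six-membered aromatic ring alone is not enough at this position: across the four compounds, the two rings of carbon only give real numbers and the two rings with hetero atoms do not, and no compound shown goes against this. Compound 1 and compound 4 each stand at a limit rather than a number, so the step between them cannot be read: the limit of > 5000 nM in this assay, at which 2 of the 4 values shown sit.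

The compounds shown do not separate the ring nitrogen from the fluorine, since both enter together; a plain pyridin-3-yl or a 2-fluorophenyl on the sulfonyl sulfur would tell which of the two goes with the loss. As far as these compounds go, it also remains open whether a ring of carbon only needs chlorine or methyl at all, a question that an unsubstituted phenyl would address.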